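Cytotoxicity at the assay limit across three analogues

A few compounds are considered here, and "the series" means these few. Any claim that something is new, unique, unknown or untested is made for them only; others in the source may bear on it.

Compound 1 `Cc1ccc(Cn2cc(COc3ccc4c(=O)ccoc4c3)nn2)cc1` gives in an ADME assay on L02 cells (Homo sapiens) for cytotoxicity, read by MTT assay, with a stated time of 48 h (a higher number here means a weaker inhibitor, a lower number a stronger inhibitor), only a limit of the assay: > 300000 nM.
Compound 2 `Cc1ccccc1Cn1cc(COc2ccc3c(=O)ccoc3c2)nn1` gives in this assay only a limit: > 300000 nM.
Compound 3 `O=c1ccoc2cc(OCc3cn(Cc4ccc(Cl)cc4Cl)nn3)ccc12` gives in this assay only a limit: > 300000 nM.

Compound 1 stands at a limit in this assay, so no number is known for it, and the same is true of compounds 2 and 3 (the limit of > 300000 nM in this assay, at which 3 of the 3 values shown sit). The three steps that join the measured compounds, a step that the two limits leave unreadable from compound 1 to compound 2, a step that the two limits leave unreadable from compound 1 to compound 3 and a step that the two limits leave unreadable from compound 2 to compound 3, each change the group on the saturated chain carbon bound to the aromatic nitrogen, yet none of them can be read, as both ends sit at the limit.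

Compound 4 `O=c1ccoc2cc(OCc3cn(Cc4cccc([N+](=O)[O-])c4)nn3)ccc12` differs from compound 1 by 3-nitrophenyl in place of 4-methylphenyl on a saturated chain carbon bound to an aromatic nitrogen. This is a change at the same place as the measured steps, and those steps give no readable size in this assay in either direction. Compound 4 is therefore expected to remain at the limit, with an estimate of 300000 nM and a range from 150000 nM to 1000000 nM. The expected step is a number no higher from compound 1 to compound 4 (the limit leaves the size open), in effect no readable change.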

Compound 4, half-maximal inhibitory concentration: > 300000 nM
Compound 4 ended at the assay's limit; the forecaster's own chance of this, stated with the estimate: 85%; the middle value sits exactly at the limit.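

Compound 4 gives in this assay only a limit, > 300000 nM. No step joining it to compound 1, compound 2 or compound 3 can be read, as all four sit at one limit: the limit of > 300000 nM in this assay, at which 4 of the 4 values shown sit.

The compounds shown leave open whether any group on the saturated chain carbon bound to an aromatic nitrogen shifts the value in this assay at all.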